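The source may hold more compounds than are shown below. What is called first, only, known or untested is meant among the compounds shown, and "the series" means these compounds.

Of the compounds shown here, three from this series have been measured in a functional assay on DU-145 cells (Homo sapiens) for inhibition, read by trypan blue exclusion, with a stated time of 96 h; on this read-out lower numbers stand for stronger inhibition of growth and higher numbers for weaker inhibition of growth. Compound 1 `Cc1ccc(S(=O)(=O)/C(=C/c2ccc(C)s2)C(=O)c2ccc(Br)cc2)cc1` gives 25000 nM. Compound 2 `O=C(/C(=C\c1c[nH]c2ccc(Cl)cc12)SCc1ccc(F)cc1)c1ccc(Br)cc1` gives 1000 nM, and compound 3 `Cc1ccc(/C=C(\C(=O)c2ccc(Br)cc2)S(=O)(=O)Cc2ccc(F)cc2)s1` gives 1000 nM. The difference between the cores of compound 2 and compound 3 is not broken down here. From compound 3 to compound 1 the change 4-methylphenyl in place of 4-fluorobenzyl on a sulfonyl sulfur produced a 25-fold higher number from compound 3 to compound 1 (1.40 log units; beyond the scatter). Compound 4 `Cc1ccc(S/C(=C/c2c[nH]c3ccc(Cl)cc23)C(=O)c2ccc(Br)cc2)cc1` has not yet been measured; it relates to compound 2 by 4-methylphenyl in place of 4-fluorobenzyl on a sulfur. This is the same kind of change, not the same: in compound 3 it sits on a sulfonyl sulfur, in compound 2 on a sulfur with a double-bonded chain carbon as its other neighbour. Among the compounds with values here, because the only measured instance is a 25-fold higher number from compound 3 to compound 1 (1.40 log units; beyond the scatter), a weakening step of similar size is expected from compound 2 to compound 4, an 8.0-fold higher number from compound 2 to compound 4 (0.90 log units; beyond the scatter). For compound 4 the estimate is 8000 nM, between 2000 nM and 40000 nM.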

Compound 4, concentration for 50% growth inhibition: 1000 nM
Compound 4: the middle estimate sits 8.0-fold (0.90 log units) above what was measured; measured number outside the range, below it.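

In this assay, 4-methylphenyl in place of 4-fluorobenzyl on a sulfur gave no change at the digits printed from compound 2 to compound 4 (within the scatter). The change therefore does not carry a fixed size from one core to the other in this series: the same change on two cores in this assay, a 25-fold higher number (1.40 log units; beyond the scatter) from compound 3 to compound 1 and no change at the digits printed (within the scatter) from compound 2 to compound 4, 25-fold (1.40 log units) apart, beyond the scatter of two such steps

The two cores differ in more than one place, and these two pairs do not show which of those differences goes with the gap between the steps. Going by these compounds, it remains open whether a sulfonyl sulfur in place of the sulfur, with the rest of the core of compound 2 kept, would restore the larger step. Also open, on these data alone, is how an amine or a longer chain in place of 4-fluorobenzyl would read on either core.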